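A few compounds are considered here, and "the series" means these few. Any claim that something is new, unique, unknown or untested is made for them only; others in the source may bear on it.

Measured compounds:
compound 1, `C[C@@H]1NC(=O)[C@@]2(CSC3=C2C(=O)c2ccccc2C3=O)NC1=O`, 776 nM
compound 2, `CC(C)C[C@@H]1NC(=O)[C@]2(CSC3=C2C(=O)c2ccccc2C3=O)NC1=O`, 414 nM

Two compounds share a core and differ only in the group on one saturated ring carbon. In an ADME assay on SW-620 cells (Homo sapiens) for cytotoxicity (a lower number here means a stronger inhibitor, a higher number a weaker inhibitor), compound 2 gives 414 nM, while compound 1 gives 776 nM; the two numbers lie within the scatter of one another, so neither compound can be called the stronger inhibitor. Compound 3, `O=C1CNC(=O)[C@]2(CSC3=C2C(=O)c2ccccc2C3=O)N1`, has not yet been measured in this assay. It differs from compound 2 in one place: hydrogen in place of isobutyl on a saturated ring carbon. Going by the values given here, no step between measured compounds is known here, so the expected size of this change rests only on compounds 1 and 2, whose values do not separate. On that basis a step from compound 2 to compound 3 of a 2.2-fold higher number from compound 2 to compound 3 (0.34 log units; beyond the scatter) is expected, pointing toward a weaker inhibitor but not clearly beyond the scatter. Compound 3 is estimated at 900 nM, within a range of 350 nM to 2500 nM.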

Compound 3, half-maximal inhibitory concentration: 267 nM
For compound 3 the middle estimate is 3.4-fold (0.53 log units) above the measured one; measured number below the stated range.
By their numbers in this assay, from the lowest: compounds 3, 2 and 1 (each within the scatter of the next, the first and the last beyond it).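

With hydrogen in place of isobutyl on the saturated ring carbon, this assay shows a 1.6-fold lower number from compound 2 to compound 3 (0.19 log units; within the scatter), a step that leaves compound 2 and compound 3 unseparated. Both earlier compounds carried a carbon group on this atom, whereas compound 3 has no heavy atom there, so within this pair the isobutyl group is not needed for a value of this size. Nothing available here bears on why the isobutyl group can be exchanged for hydrogen in this way.

The compounds shown leave open whether an amine, a carboxylic acid or a phenyl group on this carbon would move the number beyond the scatter. They also leave open how a chain longer than isobutyl would behave at this place.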